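The source may report more compounds than this note shows. Statements on the series, on what has been measured and on what is new or still open speak of the compounds shown alone.

Going by the values given here, in an ADME assay on A549 cells (Homo sapiens) for cytotoxicity, read by LDH release, with a stated time of 15 h (on this read-out lower numbers stand for higher toxicity in this test and higher numbers for lower toxicity in this test), compound 1 `CC1(Nc2ccc(NC(=O)c3cc(Cl)ccc3O)c(Cl)c2)CCCCC1` gives 86500 nM as its value and compound 2 `O=C(Nc1ccc(NCC2CCCC2)cc1Cl)c1cc(Cl)ccc1O` gives 141000 nM as its value, so compound 2 stands within the scatter of its only measured neighbour. Compound 3 `CCCC(C)(C)Nc1ccc(NC(=O)c2cc(Cl)ccc2O)c(Cl)c1` differs from compound 2 by 1,1-dimethylbutyl in place of cyclopentylmethyl on a nitrogen on an aromatic ring as the change, with 1,1-dimethylbutyl in place of cyclopentylmethyl on that nitrogen. Among the compounds with values here, the one step bearing on this, a 1.6-fold higher number from compound 1 to compound 2 (0.21 log units; within the scatter) for 1-methylcyclohexyl to cyclopentylmethyl at the same nitrogen, stayed within the scatter. An estimated 1.4-fold lower number from compound 2 to compound 3 (0.15 log units; within the scatter) in this assay is therefore expected, again within the scatter. Compound 3 is estimated at 100000 nM with 50000 nM to 200000 nM as its range.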

Compound 3, half-maximal cytotoxic concentration: 23700 nM
The estimate for compound 3 lay 4.2-fold (0.63 log units) above the measured number; the whole stated range lies above it.
By their numbers in this assay, from the lowest: compound 3; then compounds 1 and 2 (each within the scatter of the next).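

Going by these compounds alone, with 1,1-dimethylbutyl on a nitrogen on an aromatic ring, this assay shows a 5.9-fold lower number from compound 2 to compound 3 (0.77 log units; beyond the scatter) and a 3.6-fold lower number from compound 1 to compound 3 (0.56 log units; beyond the scatter) as the first steps beyond the scatter at this nitrogen. Within the data shown here, this position therefore responds to the group it carries, even with the heavy-atom count unchanged from cyclopentylmethyl to 1,1-dimethylbutyl, and the only group here with no ring gives the lowest number of the three. Nothing at hand accounts for this shift.

Still open, going by these compounds, is whether an unbranched hexyl chain on this nitrogen would give a number close to that of compound 3. Also open, on these data alone, is how a chain ending in an amine would compare.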